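The source may report more compounds than this note shows. Statements on the series, on what has been measured and on what is new or still open speak of the compounds shown alone.

Compound 1 `CC(C)(C)c1cc(NC(=O)c2c(Cl)cc(NC3CCCC3)cc2Cl)ccc1O`: > 1 h
Compound 2 `CN(c1cc(Cl)c(C(=O)Nc2ccc(O)c(C(C)(C)C)c2)c(Cl)c1)C1CCCCC1`: > 1 h

In an ADME assay on a cell-free system (serum) for metabolic stability (on this read-out lower numbers stand for a shorter-lived compound and higher numbers for a longer-lived compound), compound 2 gives > 1 h, which is a limit and not a number. Its neighbour shares that position: the limit of > 1 h in this assay, at which 2 of the 2 values shown sit.

Compound 3 `CC(C)(C)c1cc(NC(=O)c2c(Cl)cc(N3CCNCC3)cc2Cl)ccc1O` differs from compound 2 by piperazin-1-yl in place of cyclohexyl(methyl)amino on an aromatic carbon. For the measured compounds named here, the one measured step, a step that the two limits leave unreadable from compound 1 to compound 2, changes the group at this same place, but it offers no size to carry over. The expected change is therefore a step that the limit leaves unreadable from compound 2 to compound 3, with no direction supported by the data, and another limit is the likeliest report. The estimated value for compound 3 is 1.5 h, ranging from 0.6 h to 4 h.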

Compound 3, half-life: > 1 h
Compound 3: a limit, no number (the forecaster's own chance of this, stated with the estimate: 75%); the middle value does not contradict the limit.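

For the compounds shown here, compound 3 also gives a limit and not a number, so no step among compound 1, compound 2 and compound 3 can be read: the limit of > 1 h in this assay, at which 3 of the 3 values shown sit. The compounds shown leave open how long each actually lasts, and whether changing this group alters that.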